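Replacing the Amide Group of Compound 2

The compounds below may be only part of what the source reports. "The series", "measured", "known", "first", "only" and "open" are said of these compounds alone.

Compound 1 `Cc1cc(-c2ccccc2)n2nc(C(=O)Nc3sc(C)c(C)c3C(N)=O)nc2n1` gives > 250000 nM in an ADME assay on MDCK cells (Canis lupus familiaris) for cytotoxicity, read by MTT assay, with a stated time of 48 h (on this read-out higher numbers stand for lower toxicity in this test and lower numbers for higher toxicity in this test), as a limit of the assay and not a number. Among the measured compounds shown here, compound 2 `Cc1cc(-c2ccccc2)n2nc(C(=O)Nc3ccsc3C(N)=O)nc2n1` gives 250000 nM as the only actual number so far. Compound 3 `Cc1cc(-c2ccccc2)n2nc(C(=O)Nc3nc4ccccc4s3)nc2n1` has 1,3-benzothiazol-2-yl in place of 2-carbamoylthiophen-3-yl on an amide-type nitrogen and has not yet been measured. For the measured compounds named here, with no measured step to go on, the estimated change is a 1.7-fold lower number from compound 2 to compound 3 (0.22 log units; within the scatter) and is expected to stay within the usual scatter. The estimate puts compound 3 at 150000 nM with 50000 nM to 300000 nM as its expected range.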

Compound 3, half-maximal cytotoxic concentration: > 250000 nM
Compound 3: only a limit was reported (the forecaster's own chance of this, stated with the estimate: 40%); middle value at least 1.6-fold (0.22 log units) from the limit.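

At this amide-type nitrogen, 1,3-benzothiazol-2-yl in place of 2-carbamoylthiophen-3-yl gives a number no lower from compound 2 to compound 3 (the limit leaves the size open). In this assay compound 3 is reported only as a limit, > 250000 nM. The number thus stays this high without 2-carbamoylthiophen-3-yl, but the size of the change stays unreadable because the values meet a ceiling: the limit of > 250000 nM in this assay, at which 2 of the 3 values shown sit.

Going by these compounds, whether an amine or a carboxylic acid on the group at this nitrogen would bring the number down remains open. So does whether a smaller group, such as a simple methyl, would do so.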